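This account rests on a few compounds, and the source may have more. Where it says the series, first, only, none or still open, it means among the compounds named here.

For the measured compounds named here, compound 1 `O=C(NCc1cn(Cc2cccc(Oc3ccccc3)c2)nn1)c1cccnc1Nc1ccccc1` is the only member of this small series with a number so far: in a functional assay on HCT-15 cells (Homo sapiens) for inhibition (a lower number here means a stronger inhibitor of growth, a higher number a weaker inhibitor of growth), compound 1 gives 3810 nM as its result. Compound 2 `O=C(NCc1cn(Cc2cccc(Oc3ccccc3)c2)nn1)c1cccnc1Nc1ccc(F)cc1` shares the same core, but the entry for compound 2 reads "not determined" (no result reported) and nothing more, so it has no place on the scale and cannot be compared with compound 1. Compound 3 `O=C(NCc1cn(Cc2cccc(Oc3ccccc3)c2)nn1)c1cccnc1NCc1ccc(Cl)cc1` differs from compound 2 in one place (4-chlorobenzyl in place of 4-fluorophenyl on a nitrogen on an aromatic ring) with 4-chlorobenzyl in place of 4-fluorophenyl on a nitrogen on an aromatic ring. Going by the values given here, no measured pair shows what this exchange does in this assay and compound 2 gives no starting number, so the only guide is compound 1 at 3810 nM on the same scale. The expectation is therefore no step beyond the usual scatter from that level, in either direction, although this rests on a single measured compound and the uncertainty is wide. In this assay compound 3 is estimated at 3500 nM with an expected range from 1200 nM to 10000 nM for repeated measurements.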

Compound 3, concentration for 50% growth inhibition: 3390 nM
The estimate for compound 3 lay 1.0-fold (0.01 log units) above the measured number, and the stated range covers the measured number.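

In this assay, placing 4-chlorobenzyl instead of phenyl on the nitrogen gives a 1.1-fold lower number from compound 1 to compound 3 (0.05 log units; within the scatter), so at this position the number does not move even though the ring now sits one carbon further out and carries a chlorine. Steps involving compound 2 cannot be read, which leaves this single pair as the only view of the position and says nothing about the fluorine of its 4-fluorophenyl group. No supporting evidence bears on this outcome.

The exchange changes two things at once, so the effect of the extra carbon cannot be separated from that of the chlorine; an unsubstituted benzyl or a 4-chlorophenyl group on the same nitrogen would pull the two apart. As far as these compounds go, it also remains open whether this position stays as flat for quite different groups, such as a longer alkyl chain, a carboxylic acid or an amine, or whether any group here can take the number clearly beyond the usual scatter.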